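From methylsulfonyl to methanesulfonamido: a clearance question

The source may report more compounds than this note shows. Statements on the series, on what has been measured and on what is new or still open speak of the compounds shown alone.

Values measured in an ADME assay (liver) for pharmacokinetics, with Liver microsome (Rattus norvegicus) as the target, using microsomes; a higher number here means faster removal of the compound, a lower number slower removal
- compound 1 (`CNc1nc(NCc2ccc(S(C)(=O)=O)cc2)cc(-c2ccccn2)n1`): 34.1 mL/min/kg
- compound 2 (`Cc1nc(NCc2ccc(Cl)cc2)cc(-c2ccccn2)n1`): > 52.3 mL/min/kg (a limit of the assay)

Within the data shown here, compound 1 is the only compound here with an actual number (34.1 mL/min/kg). Compound 2 reports only a limit of the assay (> 52.3 mL/min/kg).

The unmeasured compound 3 (`CNc1nc(NCc2ccc(NS(C)(=O)=O)cc2)cc(-c2ccccn2)n1`) keeps the core of compound 1 and changes one group, with methanesulfonamido in place of methylsulfonyl on an aromatic carbon. This group stands para to a large group. Among the measured compounds shown here, no two measured compounds differ in just one place, so nothing yet shows directly what such a swap does. No step beyond the usual scatter is therefore expected in this assay. The expectation starts from compound 1 (34.1 mL/min/kg). The expected change is a 1.0-fold lower number from compound 1 to compound 3 (0.01 log units; within the scatter) and would stay within that scatter. For compound 3 the estimated clearance is 33 mL/min/kg (expected range 17 mL/min/kg to 52 mL/min/kg).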

Compound 3, clearance: 33.6 mL/min/kg
Compound 3: middle estimate off by 1.0-fold (0.01 log units), on the low side; the range from low to high includes it.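

In this assay, among these compounds, the exchange of methylsulfonyl for methanesulfonamido on this aromatic carbon, para to a large group, gives the first direct comparison in one place, and the step stays within the scatter (a 1.0-fold lower number from compound 1 to compound 3 (0.01 log units; within the scatter)). The entering group brings one more heavy atom, a nitrogen, and a hydrogen-bond donor, yet this position shows no readable step in clearance for that exchange. Nothing shown here accounts for this outcome.

On these data alone, whether the same holds for other groups at this position, such as an amine, a carboxylic acid or a methoxy group, stays open. The compounds shown also leave open what a longer chain in place of the methyl on the sulfonyl sulfur would do to clearance.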